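A Bromo Step on the Core of Compound 1

A few compounds are considered here, and "the series" means these few. Any claim that something is new, unique, unknown or untested is made for them only; others in the source may bear on it.

Going by the values given here, in a physicochemical assay for lipophilicity (a lower number here means a more polar compound, a higher number a more lipophilic compound), compound 1 `COc1c(OC)c(OC(C)=O)c2ccccc2c1OC(C)=O` gives 2.39 as the lowest of three numbers so far. Compound 3 `COc1c(OC)c(OC(C)=O)c2c(Cl)cccc2c1OC(C)=O` stands nearest at 3.16 and compound 2 `CCC(=O)Oc1c(Oc2ccccc2)c(Oc2ccccc2)c(OC(=O)CC)c2ccccc12` furthest at 5.8 on this scale. Compound 2 differs from compound 1 in more than one place, so it offers no clean guide. Compound 4 `COc1c(OC)c(OC(C)=O)c2cc(Br)ccc2c1OC(C)=O` is still unmeasured. It carries bromo in place of hydrogen on an aromatic carbon and this carbon is meta to a fused ring and para to a fused ring. Among the compounds with values here, the one measured step that bears on this change is a number 0.77 log units higher from compound 1 to compound 3 (beyond the scatter) for chloro in place of hydrogen on an aromatic carbon. That step is modest but beyond the scatter. Within the data shown here, no bromo compound has been measured, and the chloro of compound 3 sits on a different carbon, so the comparison is imperfect. A modest rise of similar or slightly larger size is therefore expected, and the estimated step is a number 0.91 log units higher from compound 1 to compound 4 (beyond the scatter) in this assay for now. For compound 4 the estimated value is 3.3 with an expected range from 2.9 to 3.75 in this measurement.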

Compound 4, partition coefficient: 3.39
For compound 4 the middle estimate is 0.09 log units below the measured one; low and high end bracket the measured number.
By their numbers in this assay, from the lowest: compound 1; then compounds 3 and 4 (each within the scatter of the next); then compound 2.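

In this assay, bromo in place of hydrogen on an aromatic carbon, on the carbon meta to a fused ring and para to a fused ring, gives a number 1.00 log units higher from compound 1 to compound 4 (beyond the scatter) on the shared core. Going by these compounds alone, this is the first reading for this carbon and for a bromo group, and it shows that a change here also moves the number beyond the scatter, as did the chloro change on a different carbon, with a number 0.77 log units higher from compound 1 to compound 3 (beyond the scatter). No measurement at hand accounts for the size of the bromo step.

The compounds shown leave open how chloro would read on this same carbon and how bromo would read on the carbon that carries chloro in compound 3, so group and position cannot yet be told apart. An amine or a carboxylic acid in place of hydrogen on this carbon would show whether the number can also fall below that of compound 1.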